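The source may hold more compounds than are shown below. What is called first, only, known or untested is meant among the compounds shown, and "the series" means these compounds.

Measured so far:
compound 1 `CCS(=O)(=O)Nc1cc(-c2ccc3ncnc(Nc4ccc(F)cc4F)c3c2)cnc1OC`, 2480 nM
compound 2 `CCS(=O)(=O)Nc1cc(-c2ccc3ncnc(Nc4ccc(OC(F)(F)F)cc4)c3c2)cnc1OC`, 8240 nM
compound 3 `CCS(=O)(=O)Nc1cc(-c2ccc3ncnc(Nc4ccc(OC)cc4)c3c2)cnc1OC`, 1880 nM

In a functional assay on BT-549 cells (Homo sapiens) for cytotoxicity, read by sulforhodamine B assay, with a stated time of 72 h (a lower number here means a stronger inhibitor, a higher number a weaker inhibitor), compound 3 gives the lowest of the three numbers; compound 1 sits within the scatter of it (a 1.3-fold lower number from compound 1 to compound 3 (0.12 log units; within the scatter)), whereas compound 2 lies beyond it (a 4.4-fold lower number from compound 2 to compound 3 (0.64 log units; beyond the scatter)). Compound 4 `CCS(=O)(=O)Nc1cc(-c2ccc3ncnc(Nc4ccc(F)c(C(=O)OC)c4)c3c2)cnc1OC` carries the change (4-fluoro-3-(methoxycarbonyl)phenyl in place of 4-methoxyphenyl on a nitrogen on an aromatic ring). Within the data shown here, no measured step exchanges this group in the same way; the steps that bear on it are the other exchanges on the same nitrogen, a 3.3-fold higher number from compound 1 to compound 2 (0.52 log units; beyond the scatter) and a 1.3-fold lower number from compound 1 to compound 3 (0.12 log units; within the scatter), together with a 4.4-fold lower number from compound 2 to compound 3 (0.64 log units; beyond the scatter), none larger than modest. A step of comparable size is therefore expected, more likely toward a higher number than a lower one, and compound 4 is expected at 3000 nM (range 1200 nM to 8000 nM), a step of a 1.6-fold higher number from compound 3 to compound 4 (0.20 log units; within the scatter).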

Compound 4, half-maximal inhibitory concentration: 2740 nM
Compound 4: the middle estimate sits 1.1-fold (0.04 log units) above what was measured, within the range that was stated.
By their numbers in this assay, from the lowest: compounds 3, 1 and 4 (each within the scatter of the next); then compound 2.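

In this assay, among these compounds, 4-fluoro-3-(methoxycarbonyl)phenyl, the only group here with a double bond outside aromatic rings, leaves the number within the scatter of the two nearest compounds: a 1.5-fold higher number from compound 3 to compound 4 (0.16 log units; within the scatter) and a 1.1-fold higher number from compound 1 to compound 4 (0.04 log units; within the scatter). Only the 4-(trifluoromethoxy)phenyl compound stands apart, with a 3.0-fold lower number from compound 2 to compound 4 (0.48 log units; beyond the scatter). Nothing available explains these differences.

As far as these compounds go, the separate contributions of the fluorine and the methoxycarbonyl remain open. So does whether a carboxylic acid or an amide in place of the methoxycarbonyl would keep the number in this range.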